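Exchanging a dichlorophenyl-ethenyl arm for 3-methylphenyl

This account rests on a few compounds, and the source may have more. Where it says the series, first, only, none or still open, it means among the compounds named here.

Measured compounds:
compound 1 `COC(=O)/C=C/c1cccc(N(Cc2ccc(/C=C/c3c(Cl)cccc3Cl)cc2)C(=O)C(C)C)c1`: 195 nM
compound 2 `COC(=O)/C=C/c1cccc(N(Cc2ccc(-c3cccc(Cl)c3)cc2)C(=O)C2CCCCC2)c1`: 94 nM

The study reads the two compounds in an assay on isolated protein with Bile acid receptor (Homo sapiens) as the target; on this read-out higher numbers stand for an effect only at larger amounts of compound and lower numbers for an effect already at smaller amounts. Compound 1 gives 195 nM, the highest of the two numbers shown. Going by the values given here, its nearest neighbour is compound 2, which in this assay gives 94 nM, a lower number by a margin that lies beyond the usual scatter; no single-point step links these two compounds, as they differ in more than one place, so only their two values can be compared.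

The piece now follows compound 1 to the as yet unmeasured compound 3 `COC(=O)/C=C/c1cccc(N(Cc2ccc(-c3cccc(C)c3)cc2)C(=O)C(C)C)c1`. The change is 3-methylphenyl in place of 2-(2,6-dichlorophenyl)ethenyl on an aromatic carbon. Among the compounds with values here, since the data hold no measured step that isolates this change, the expectation rests on the two values alone. Because compound 2 gives 94 nM with a different group at the same place, a modest move toward a lower number is expected for compound 3, though one that may well stay within the scatter: the expected step is a 1.4-fold lower number from compound 1 to compound 3 (0.14 log units; within the scatter). For compound 3 in this assay the estimate is 140 nM, with a range from 50 nM to 400 nM.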

Compound 3, half-maximal effective concentration: 163 nM
Estimate against measurement, compound 3: 1.2-fold (0.07 log units) below; the measured number falls inside the stated range.
By their numbers in this assay, from the lowest: compounds 2, 3 and 1 (each within the scatter of the next, the first and the last beyond it).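

In this assay, going by these compounds alone, this is the first comparison in which only one place differs, and the step reads a 1.2-fold lower number from compound 1 to compound 3 (0.08 log units; within the scatter). At this aromatic carbon, para to a large group, the 2-(2,6-dichlorophenyl)ethenyl arm, with its 10 heavy atoms, two chlorines and a double bond outside the aromatic ring, can therefore give way to the 7-carbon 3-methylphenyl group without a change that the read-out can separate from the scatter, so neither the chlorines nor that double bond is needed here to keep a value of this order. No evidence is available to explain why the two groups read alike.

Compound 2 differs from compound 3 in more than one place, so the compounds shown do not tell how much of its value belongs to the group at this position and how much to the acyl group on the nitrogen. On these data alone, it also remains open whether this tolerance extends beyond the groups seen so far, for example to a phenyl ring carrying an amine or a carboxylic acid in place of the methyl.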